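The source may hold more compounds than are shown below. What is called first, only, known or untested is meant among the compounds shown, and "the series" means these compounds.

Measured compounds:
compound 1 `CC1=C(/C=C/C(=O)/C=C/c2cccc(C(F)(F)F)c2)C(C)(C)CCC1O`: 740 nM
compound 2 `CC1=C(/C=C/C(=O)/C=C/c2cc(C(F)(F)F)cc(C(F)(F)F)c2)C(C)(C)CCC1O`: 2100 nM
compound 3 `CC1=C(/C=C/C(=O)/C=C/c2cccc(F)c2)C(C)(C)CCC1O`: 4400 nM

All three share a core and differ only in the groups on the aromatic ring. In a functional assay on LNCaP cells (Homo sapiens) for cytotoxicity, read by MTT assay, with a stated time of 72 h (a lower number here means a stronger inhibitor, a higher number a weaker inhibitor), compound 3 gives the highest number of the three, meaning the weakest inhibition; compound 2 is nearest, and compound 1 furthest, as the step of a 5.9-fold higher number from compound 1 to compound 3 (0.77 log units; beyond the scatter) shows.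

Compound 4 `CC1=C(/C=C/C(=O)/C=C/c2cc(F)cc(C(F)(F)F)c2)C(C)(C)CCC1O` is compound 3 with one change: trifluoromethyl in place of hydrogen on an aromatic carbon. Within the data shown here, two measured steps bear on this. Adding a trifluoromethyl to a ring that already carries one gave a 2.8-fold higher number from compound 1 to compound 2 (0.45 log units; beyond the scatter), a weakening. Replacing trifluoromethyl by fluoro gave a 5.9-fold higher number from compound 1 to compound 3 (0.77 log units; beyond the scatter), also a weakening; the reverse of that, trifluoromethyl regained, would be a strengthening. Compound 4 ends up carrying both fluoro and trifluoromethyl, so its number is expected to fall between those of compound 1 and compound 3, nearer compound 2, a step of a 2.9-fold lower number from compound 3 to compound 4 (0.47 log units; beyond the scatter) towards stronger inhibition. Compound 4 is therefore estimated at 1500 nM in this assay, within 500 nM to 4500 nM.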

Compound 4, half-maximal inhibitory concentration: 1100 nM
Estimate against measurement, compound 4: 1.4-fold (0.13 log units) above; the measured number falls inside the stated range.
By their numbers in this assay, from the lowest: compounds 1, 4 and 2 (each within the scatter of the next, the first and the last beyond it); then compound 3.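

In this assay, adding trifluoromethyl to the fluoro-bearing ring strengthens inhibition (a 4.0-fold lower number from compound 3 to compound 4 (0.60 log units; beyond the scatter)), the opposite of what the same addition did on the ring already holding trifluoromethyl, so this change has no fixed direction here: (the same change on two cores in this assay, a 2.8-fold higher number (0.45 log units; beyond the scatter) from compound 1 to compound 2 and a 4.0-fold lower number (0.60 log units; beyond the scatter) from compound 3 to compound 4, 11-fold (1.06 log units) apart, beyond the scatter of two such steps). Fluoro in place of one trifluoromethyl likewise depends on its surroundings, staying within the scatter when a second group remains on the ring (a 1.9-fold lower number from compound 2 to compound 4 (0.28 log units; within the scatter)) but not when it is the only group: (the same change on two cores in this assay, a 5.9-fold higher number (0.77 log units; beyond the scatter) from compound 1 to compound 3 and a 1.9-fold lower number (0.28 log units; within the scatter) from compound 2 to compound 4, 11-fold (1.06 log units) apart, beyond the scatter of two such steps). Fluoro in place of hydrogen on the trifluoromethyl ring also stays within the scatter (a 1.5-fold higher number from compound 1 to compound 4 (0.17 log units; within the scatter)), so the effects of these groups do not simply add up.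

The ring groups shown are only fluoro and trifluoromethyl, so it remains open whether an amine, a methoxy or a carboxylic acid at this place would behave the same way. What lies behind the reversal also remains open.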